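Swapping Dichlorophenyl for Methoxyphenyl on the Allyl Core

The compounds below may be only part of what the source reports. "The series", "measured", "known", "first", "only" and "open" are said of these compounds alone.

Compound 1 `COc1ccccc1/C=c1/[nH]c(=O)/c(=C\c2ccccc2OC)n(C)c1=O` carries two 2-methoxyphenyl groups, and in a functional assay on MCF7 cells (Homo sapiens) for cytotoxicity, read by CCK-8 assay, with a stated time of 72 h (a higher number here means a weaker inhibitor, a lower number a stronger inhibitor), compound 1 gives 9000 nM. Compound 2 `C=CCn1c(=O)/c(=C\c2ccccc2Cl)[nH]c(=O)/c1=C\c1ccccc1OC`, with one 2-chlorophenyl arm, gives 4700 nM in this assay. Compound 3 `C=CCn1c(=O)/c(=C\c2ccc(Cl)c(Cl)c2)[nH]c(=O)/c1=C\c1ccccc1OC` gives "not active" (no number reported) in this assay; no number was reported for it, so it cannot be placed on the scale beside compounds 1 and 2. Compound 4 `C=CCn1c(=O)/c(=C\c2ccccc2OC)[nH]c(=O)/c1=C\c1ccccc1OC` differs from compound 3 by 2-methoxyphenyl in place of 3,4-dichlorophenyl on a double-bonded chain carbon bound to an aromatic carbon. For the measured compounds named here, no measured step covers this change. Because compound 1 reaches 9000 nM and compound 2 reaches 4700 nM in this assay, compound 4 is expected to move from inactive to a measurable value, a step well beyond the scatter. Compound 4 is estimated at 6500 nM, within 2500 nM to 16000 nM.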

Compound 4, half-maximal inhibitory concentration: 41100 nM
For compound 4 the middle estimate is 6.3-fold (0.80 log units) below the measured one, and the stated range ends below it.
By their numbers in this assay, from the lowest: compounds 2 and 1 (each within the scatter of the next); then compound 4.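

In this assay, 2-methoxyphenyl in place of 3,4-dichlorophenyl gives compound 4 a measurable number where compound 3 has none, but not a low one: an 8.7-fold higher number from compound 2 to compound 4 (0.94 log units; beyond the scatter) goes with methoxy in place of chloro on an aromatic carbon. Likewise, a 4.6-fold higher number from compound 1 to compound 4 (0.66 log units; beyond the scatter) goes with vinyl in place of hydrogen on a saturated chain carbon bound to an aromatic nitrogen. No supporting measurement accounts for either shift. The compounds shown leave open how an aromatic ring carrying an amine or a carboxylic acid would read on this double-bonded chain carbon.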